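Carbamate series: propargyl to benzyl, amine oxidase A inhibition

The source may report more compounds than this note shows. Statements on the series, on what has been measured and on what is new or still open speak of the compounds shown alone.

Compound 1 `C#CCN1CCC(OC(=O)Nc2ccccc2)CC1` and compound 2 `O=C(Nc1ccccc1)OC1CCN(Cc2ccccc2)CC1` share one core; compound 3 `C#CCN1CCC(COC(=O)Nc2ccc(C(C)C)cc2)CC1` and compound 4 `CC(C)c1ccc(NC(=O)OCC2CCN(Cc3ccccc3)CC2)cc1` share another. The difference between the two cores is not broken down here.

In an assay on BTI-TN-5B1-4 cells for inhibition of Amine oxidase [flavin-containing] A (Homo sapiens), read by fluorescence and Amplex Red, using microsomes, with a stated time of 15 min (a lower number here means a stronger inhibitor, a higher number a weaker inhibitor), compound 1 gives > 100000 nM, which is a limit of the assay and not a number. Compound 2 likewise gives only a limit, > 100000 nM. The change from compound 1 to compound 2 is phenyl in place of ethynyl on a saturated chain carbon bound to an amine nitrogen in a ring, and the step it made is a step that the two limits leave unreadable from compound 1 to compound 2. Compound 3 also gives only a limit, > 100000 nM. All three measured values sit at the limit of > 100000 nM in this assay, at which 3 of the 3 values shown sit, so nothing in the series has yet shown measurable inhibition.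

Compound 4 carries the same change as compound 2, (phenyl in place of ethynyl on a saturated chain carbon bound to an amine nitrogen in a ring), at the same place, on top of the core of compound 3. Because the measured step that the two limits leave unreadable from compound 1 to compound 2 cannot be read, the change itself gives no direction. What remains is that every compound shown, compound 1, compound 2 and compound 3, stands at the limit, and the change has not yet pulled a value below it.

Compound 4 is therefore expected to remain at the limit, with an estimate of 200000 nM and a range from 60000 nM to 1000000 nM. The step that this estimate means, a step that the limit leaves unreadable from compound 3 to compound 4, is expected to be no larger than the unreadable step seen before.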

Compound 4, half-maximal inhibitory concentration: > 100000 nM
Compound 4: only a limit was reported; the forecaster's own chance of this, stated with the estimate: 85%; the middle value lies beyond the limit too.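

Going by these compounds alone, compound 3 and compound 4 each give only a limit of the assay and not a number, so no step between them can be read in this assay, and the same holds for compound 1 and compound 2. The series stays where it was: the limit of > 100000 nM in this assay, at which 4 of the 4 values shown sit.

The compounds shown leave open whether propargyl to benzyl alters inhibition in either core, and what would bring a value inside the limit.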